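Methoxy for bromo on the benzyl ring of compound 2

The source may hold more compounds than are shown below. What is called first, only, known or untested is meant among the compounds shown, and "the series" means these compounds.

Compound 1 `O=S(=O)(NCCCNCc1ccc(C(F)(F)F)cc1)c1cc(C(F)(F)F)cc(C(F)(F)F)c1` gives 2700 nM in a functional assay on HPAC cells (Homo sapiens) for inhibition, read by MTT assay, with a stated time of 72 h; on this read-out higher numbers stand for weaker inhibition of growth and lower numbers for stronger inhibition of growth. Compound 2 `O=S(=O)(NCCCNCc1ccc(Br)cc1)c1cc(C(F)(F)F)cc(C(F)(F)F)c1`, with bromo in place of trifluoromethyl on an aromatic carbon, gives 2900 nM in this assay; the step of a 1.1-fold higher number from compound 1 to compound 2 (0.03 log units; within the scatter) lies within the scatter, so compound 2 holds the higher of the two numbers only nominally, compound 1 sitting nearest. Compound 3 `COc1ccc(CNCCCNS(=O)(=O)c2cc(C(F)(F)F)cc(C(F)(F)F)c2)cc1` differs from compound 2 by methoxy in place of bromo on an aromatic carbon. Among the compounds with values here, the only step that bears on this, a 1.1-fold higher number from compound 1 to compound 2 (0.03 log units; within the scatter), also a change on an aromatic carbon, stayed within the scatter; the expectation in this assay is accordingly no step beyond the scatter: a 1.0-fold higher number from compound 2 to compound 3 (0.01 log units; within the scatter). Compound 3 is estimated at 3000 nM, between 1200 nM and 7500 nM.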

Compound 3, concentration for 50% growth inhibition: 3000 nM
Beside the measured number, compound 3's estimate shows no gap at the digits printed; measured number inside the range.
By their numbers in this assay, from the lowest: compounds 1, 2 and 3 (each within the scatter of the next).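

Methoxy on this aromatic carbon, para to a large group, reads the same as bromo in this assay (a 1.0-fold higher number from compound 2 to compound 3 (0.01 log units; within the scatter)). Within the data shown here, it also reads the same as trifluoromethyl (a 1.1-fold higher number from compound 1 to compound 3 (0.05 log units; within the scatter)), so three groups at this position now lie within the scatter of one another, where the earlier compounds offered only two. Nothing on hand accounts for this lack of separation. Open, from the compounds shown here alone, is whether an amine or a carboxylic acid at this position would move the number, and whether these three groups would still read alike with a longer chain in the core.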